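Fluoro scan on the aryl ring of compound 1

The source may hold more compounds than are shown below. What is called first, only, known or untested is meant among the compounds shown, and "the series" means these compounds.

Measured so far:
compound 1 `C[C@H](Nc1ncnc2[nH]cnc12)c1nn(-c2cccc(F)c2)c2cc(F)ccc12`: 28%
compound 2 `C[C@H](Nc1nc(N)nc(N)c1C#N)c1nn(-c2cccc(S(C)(=O)=O)c2)c2cc(Cl)ccc12`: 72%
compound 3 `C[C@H](Nc1nc(N)nc(N)c1C#N)c1nn(-c2cccnc2)c2cc(C(F)(F)F)ccc12`: 69%

In a functional assay on Hep 3B2 cells (Homo sapiens) for inhibition, read by sulforhodamine B assay, with a stated time of 72 h, tested at 10 uM (on this read-out lower numbers stand for less inhibition and higher numbers for more inhibition at the one concentration tested (going by the name of the read-out)), compound 1 stands lowest of the three numbers; compound 3 lies higher by a margin beyond the scatter, and compound 2 lies higher still, also beyond the scatter. No two of these compounds differ in one place only, so no single step is known from the measured set.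

Compound 4 `C[C@H](Nc1ncnc2[nH]cnc12)c1nn(-c2cc(F)cc(F)c2)c2cc(F)ccc12` differs from compound 1 by fluoro in place of hydrogen on an aromatic carbon.

Among the measured compounds shown here, with no comparable step in hand, the change from compound 1 to compound 4 is expected to be small, a number 4 percentage points higher from compound 1 to compound 4 (within the scatter), and most likely not beyond the scatter in either direction. Compound 4 is therefore estimated at 32%, within a range of 14% to 54%.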

Compound 4, a percentage reported as inhibition, at one concentration (the size of the read-out at that concentration, not a potency): 14%
The estimate for compound 4 lay 18 percentage points above the measured number; the range from low to high includes it.
By their numbers in this assay, from the lowest: compound 4; then compound 1; then compounds 3 and 2 (each within the scatter of the next).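

In this assay, the change from 3-fluorophenyl to 3,5-difluorophenyl gives a number 14 percentage points lower from compound 1 to compound 4 (beyond the scatter), the first single-place step known in this series. The position, meta to a fluoro group on the aromatic ring, is therefore not indifferent to substitution: adding one fluoro is enough to lower the number beyond the scatter. Nothing at hand accounts for this drop. As far as these compounds go, it remains open whether a methoxy group or an amine at the same position would also lower the number, and whether the fluoro step would carry over to the core of compound 2.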